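Shrinking a Piperazine Substituent Down to Dimethylamino

The source may hold more compounds than are shown below. What is called first, only, known or untested is meant among the compounds shown, and "the series" means these compounds.

Two compounds have been measured in an assay on isolated protein for displacement of a labelled ligand from 5-hydroxytryptamine receptor 6 (Homo sapiens), read by scintillation counting, with a stated time of 1 h; on this read-out lower numbers stand for stronger inhibition and higher numbers for weaker inhibition:
Compound 1 `COc1cccc2c1ccn2S(=O)(=O)c1ccccc1` gives 262 nM
Compound 2 `CC(=O)N1CCN(c2cccc3c2ccn3S(=O)(=O)c2ccccc2)CC1` gives 714 nM

Among the measured compounds shown here, compound 2 stands at the higher, weaker end of these two numbers; the single measured step, a 2.7-fold higher number from compound 1 to compound 2 (0.44 log units; beyond the scatter), shows that replacing methoxy with the larger 4-acetylpiperazin-1-yl cost some binding. Compound 3 `CN(C)c1cccc2c1ccn2S(=O)(=O)c1ccccc1` is not yet measured. It differs from compound 2 by dimethylamino in place of 4-acetylpiperazin-1-yl on an aromatic carbon. For the measured compounds named here, the dimethylamino group is far closer in size to the methoxy of compound 1 than to the ring that leaves, so the only relevant step is the one from compound 1 to compound 2, read in reverse. Compound 3 is therefore expected to recover most of that loss, a step of about a 2.4-fold lower number from compound 2 to compound 3 (0.38 log units; beyond the scatter) in this assay, giving an estimated 300 nM with a plausible range from 100 nM to 900 nM.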

Compound 3, inhibition constant: 65 nM
For compound 3 the middle estimate is 4.6-fold (0.66 log units) above the measured one, and the stated range ends above it.
By their numbers in this assay, from the lowest: compound 3; then compound 1; then compound 2.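

In this assay the exchange of 4-acetylpiperazin-1-yl for dimethylamino gives an 11-fold lower number from compound 2 to compound 3 (1.04 log units; beyond the scatter) and shows how strongly the group on this aromatic carbon can shift the number. Dimethylamino also outperforms methoxy with a 4.0-fold lower number from compound 1 to compound 3 (0.61 log units; beyond the scatter) and makes compound 3 the strongest of the three, so a change at this position can improve on compound 1 as well as lose ground to it. Attachment through nitrogen does not by itself bring strength, since compound 2 is also joined through nitrogen and is the weakest, and nothing available here explains these differences.

The compounds shown leave open whether the acetyl group or the piperazine ring accounts for the weakness of compound 2, which an unsubstituted piperazine could help to separate. They also leave open how a primary amine or a diethylamino group would compare with dimethylamino at this position.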